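This account rests on a few compounds, and the source may have more. Where it says the series, first, only, none or still open, it means among the compounds named here.

Working notes on the series. Compound 1 `CCCCCCCCc1ccc(OC(C)C(=O)Cn2nnc(-c3ccc(Cl)cc3)n2)cc1` gives only the assay limit > 8 in a physicochemical assay for lipophilicity, read by HPLC, tested at 5 mM (on this read-out lower numbers stand for lower lipophilicity and higher numbers for higher lipophilicity), so it is a limit and not a number. Compound 2 `CC(Oc1ccc(Oc2ccc(F)cc2)cc1)C(=O)Cn1nnc(-c2ccc(Cl)cc2)n1` gives 6.2 in this assay. Compound 3 `CC(Oc1ccc(Oc2ccc(Cl)cc2)cc1)C(=O)Cn1nnc(-c2ccc(Cl)cc2)n1` gives 6.8 in this assay, the highest of the two numbers in hand; the nearest is compound 2, and the step of a number 0.60 log units higher from compound 2 to compound 3 (beyond the scatter) is a modest one beyond the scatter. The two larger steps, a number at least 1.80 log units lower from compound 1 to compound 2 (beyond the scatter) and a number at least 1.20 log units lower from compound 1 to compound 3 (beyond the scatter), start from a limit of > 8 in this assay, at which 1 of the 3 values shown sits, and only bound the size of the change.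

Compound 4 `CC(Oc1ccc(Oc2ccc(C(F)(F)F)cc2)cc1)C(=O)Cn1nnc(-c2ccc(Cl)cc2)n1` differs from compound 3 by trifluoromethyl in place of chloro on an aromatic carbon. Within the data shown here, the one step that bears on this kind of change, a swap of one halogen for another at the same place, is a number 0.60 log units higher from compound 2 to compound 3 (beyond the scatter), which was modest. The swap of chloro for trifluoromethyl is of the same type, and the step is therefore expected to be small, in the upward direction, likely within the scatter. Compound 4 is expected to give about 7 in this assay, between 6.5 and 7.6, which means an expected step of a number 0.20 log units higher from compound 3 to compound 4 (within the scatter).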

Compound 4, partition coefficient: 7
The estimate for compound 4 equals the measured number at the digits printed, within the range that was stated.
By their numbers in this assay, from the lowest: compound 2; then compounds 3 and 4 (each within the scatter of the next). At a limit, above all of these: compound 1.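

At this place, on an aromatic carbon of a six-membered aromatic ring of carbon only and para to a large group, the step of a number 0.20 log units higher from compound 3 to compound 4 (within the scatter) shows that trifluoromethyl in place of chloro, with 4 heavy atoms entering for 1 leaving, brings no change that can be separated in this assay. Among these compounds, with the further step a number 0.80 log units higher from compound 2 to compound 4 (beyond the scatter), fluoro is the one group of the three at this place that stands apart from the others, while chloro and trifluoromethyl cannot be told apart on this read-out. The remaining step, a number at least 1.00 log units lower from compound 1 to compound 4 (beyond the scatter), starts from a limit and not a number, so it only bounds the change: the limit of > 8 in this assay, at which 1 of the 4 values shown sits.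

On these data alone, it remains open whether a group of a different kind at this place, such as an amine, a carboxylic acid or a nitrile, would move the number outside the narrow band held by the three aryl ether compounds. Also open is whether a swap of the same kind elsewhere on the shared core, where the other chloro stays fixed in all the compounds shown, would give steps of similar size.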